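Thiophene for Tolyl on the Longer Chain

The source may hold more compounds than are shown below. What is called first, only, known or untested is meant among the compounds shown, and "the series" means these compounds.

Compound 1 `CCCCCCCCCCCCCCNC(=O)[C@@H](NS(=O)(=O)c1ccc(C)cc1)[C@@H](C)O` was tested in a functional assay on A-431 cells (Homo sapiens) for cytotoxicity, read by MTT assay, with a stated time of 48 h (on this read-out lower numbers stand for stronger inhibition and higher numbers for weaker inhibition), and gives 12000 nM. Compound 2 `CCCCCCCCCCCCCCNC(=O)[C@@H](NS(=O)(=O)c1cccs1)[C@@H](C)O` differs from compound 1 only by thiophen-2-yl in place of 4-methylphenyl on a sulfonyl sulfur; in this assay compound 2 gives 22000 nM, and the step of a 1.8-fold higher number from compound 1 to compound 2 (0.26 log units; within the scatter) lies within the usual scatter of repeated measurements. Compound 3 `CCCCCCCCCCCCCCCCCCNC(=O)[C@@H](NS(=O)(=O)c1ccc(C)cc1)[C@@H](C)O` keeps the (4-methylphenyl)sulfonyl group of compound 1 but has a different core, the difference being (butyl in place of hydrogen on a saturated chain carbon, ten or more bonds along the chain from an amide-type nitrogen); in this assay compound 3 gives 34000 nM, a step of a 2.8-fold higher number from compound 1 to compound 3 (0.45 log units; beyond the scatter) that goes beyond the scatter. Compound 4 `CCCCCCCCCCCCCCCCCCNC(=O)[C@@H](NS(=O)(=O)c1cccs1)[C@@H](C)O` has not been measured. It relates to compound 3 exactly as compound 2 relates to compound 1: the change thiophen-2-yl in place of 4-methylphenyl on a sulfonyl sulfur is the same change, made at the same place, only on the longer core. Because the same change gave a 1.8-fold higher number from compound 1 to compound 2 (0.26 log units; within the scatter), a step of similar size is expected here, a 1.8-fold higher number from compound 3 to compound 4 (0.25 log units; within the scatter), which would itself sit within the scatter. Compound 4 is therefore estimated at 60000 nM, with a likely range from 25000 nM to 150000 nM.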

Compound 4, half-maximal inhibitory concentration: > 200000 nM
Compound 4 gave a limit, no number (the forecaster's own chance of this, stated with the estimate: 20%); at least 3.3-fold (0.52 log units) between middle value and limit.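

On these data alone, compound 4 gives only a limit of the assay, > 200000 nM, not a number, so the true size of both its steps stays unknown and only their lower ends can be read. Even so, thiophen-2-yl in place of 4-methylphenyl does not carry over from the shorter core to the longer one at the same size, since in this assay the new step is an at least 5.8-fold higher number from compound 3 to compound 4 (0.76 log units; beyond the scatter), and the two steps differ: the same change on two cores in this assay, a 1.8-fold higher number (0.26 log units; within the scatter) from compound 1 to compound 2 and an at least 5.8-fold higher number (0.76 log units; beyond the scatter) from compound 3 to compound 4, at least 3.2-fold (0.50 log units) apart, beyond the scatter of two such steps Read the other way, lengthening the chain also costs more with thiophen-2-yl on the sulfonyl sulfur than with 4-methylphenyl, at an at least 9.0-fold higher number from compound 2 to compound 4 (0.95 log units; beyond the scatter), though these four compounds cover only two groups on two cores and give no reason for the gap: the same change on two cores in this assay, a 2.8-fold higher number (0.45 log units; beyond the scatter) from compound 1 to compound 3 and an at least 9.0-fold higher number (0.95 log units; beyond the scatter) from compound 2 to compound 4, at least 3.2-fold (0.50 log units) apart, beyond the scatter of two such steps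

As far as these compounds go, whether the gap between the steps grows steadily with chain length remains open, as a chain of intermediate length could show. From the compounds shown here alone, whether it holds for other groups on the sulfonyl sulfur, such as a plain phenyl or a methyl, is also open.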